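This account rests on a few compounds, and the source may have more. Where it says the series, first, only, none or still open, it means among the compounds named here.

In an ADME assay on cells (Fibroblast, Homo sapiens) for cytotoxicity, with a stated time of 48 h (on this read-out higher numbers stand for weaker inhibition and lower numbers for stronger inhibition), compound 1 (`COc1cc(OC)c(C(=O)/C=C/c2ccccc2OC)c(OC)c1`) gives 8200 nM. Compound 2 (`COc1cccc(/C=C/C(=O)c2c(OC)cc(OC)cc2OC)c1`) reads > 20000 nM, which is a limit of the assay and not a number. Compound 3 (`COc1cc(OC)c(C(=O)/C=C/c2ccc(F)cc2)c(OC)c1`) reads > 20000 nM, also a limit, so it has no exact position. Compound 4 (`COc1cc(OC)c(C(=O)/C=C/c2ccc(Br)cc2)c(OC)c1`) differs from compound 3 by one change: bromo in place of fluoro on an aromatic carbon. The nearest evidence is an at least 2.4-fold higher number from compound 1 to compound 3 (0.38 log units; beyond the scatter), alongside an at least 2.4-fold higher number from compound 1 to compound 2 (0.38 log units; beyond the scatter). Both are at least modest, whereas a step that the two limits leave unreadable from compound 2 to compound 3. None of these steps swaps fluoro for bromo, so no step beyond the scatter is expected in this assay, and no direction is expected. The expected change is a number no higher from compound 3 to compound 4 (the limit leaves the size open). Compound 4 is estimated at 20000 nM, with an expected range of 8000 nM to 50000 nM.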

Compound 4, half-maximal inhibitory concentration: > 20000 nM
Compound 4 gave a limit, no number; the forecaster's own chance of this, stated with the estimate: 55%; the middle value sits exactly at the limit.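

In this assay, bromo in place of fluoro on an aromatic carbon, para to a large group, yields a second limit and no number, so the steps among compound 2, compound 3 and compound 4 cannot be read. Going by these compounds alone, the one readable new step is an at least 2.4-fold higher number from compound 1 to compound 4 (0.38 log units; beyond the scatter). With this change, the series gathers at one boundary: the limit of > 20000 nM in this assay, at which 3 of the 4 values shown sit.

On these data alone, whether compound 2, compound 3 and compound 4 differ from one another remains open. So does how an amine or a carboxylic acid at this place would read.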